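This account rests on a few compounds, and the source may have more. Where it says the series, first, only, none or still open, it means among the compounds named here.

In an ADME assay on J774.A1 cells (Mus musculus) for cytotoxicity (a higher number here means that more compound is tolerated, a lower number that less compound is tolerated), compound 1 `Fc1ccc(N2CCN(c3nc(-n4ccc5ccccc54)c4ccccc4n3)CC2)cc1` gives 23.4 ug/mL. Compound 2 `COc1ccc(-c2nc(N3CCNCC3)nc3ccccc23)c(OC)c1` gives 3.98 ug/mL in the same read-out. Within the data shown here, compound 1 stands highest of the two numbers so far, and its gap to compound 2 lies beyond the scatter. Compound 3 `c1ccc2c(c1)ccn2-c1nc(N2CCNCC2)nc2ccccc12` differs from compound 1 by hydrogen in place of 4-fluorophenyl on an amine nitrogen in a ring with hydrogen in place of 4-fluorophenyl on an amine nitrogen in a ring. Among the measured compounds shown here, no measured pair isolates this change. A fall beyond the scatter in this assay is expected, since compound 2 with hydrogen on that nitrogen gives 3.98 ug/mL there. The expected step is a 3.9-fold lower number from compound 1 to compound 3 (0.59 log units; beyond the scatter) in size. Compound 3 is estimated at 6 ug/mL with a range of 2.5 ug/mL to 15 ug/mL as the likely span.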

Compound 3, half-maximal cytotoxic concentration: 3.11 ug/mL
For compound 3 the middle estimate is 1.9-fold (0.29 log units) above the measured one; the measured number falls inside the stated range.
By their numbers in this assay, from the lowest: compounds 3 and 2 (each within the scatter of the next); then compound 1.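

Hydrogen in place of 4-fluorophenyl on the amine nitrogen in the ring gives a 7.5-fold lower number from compound 1 to compound 3 (0.88 log units; beyond the scatter) in this assay, the first step in the series that isolates this position. With the rest of the structure unchanged, the higher tolerated concentration therefore goes with the 4-fluorophenyl group, a link that the earlier pair, differing in more than one place, could not show. No available data bear on the reason for this step. From the compounds shown here alone, whether a methyl group or an unsubstituted phenyl on that nitrogen keeps the higher number remains open.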